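A few compounds are considered here, and "the series" means these few. Any claim that something is new, unique, unknown or untested is made for them only; others in the source may bear on it.

Working notes on the series. Among the compounds with values here, compound 1 `COc1nc2ccc(Br)cc2cc1C(c1ccccc1)n1cc(-c2ccc(Br)cc2)nn1` is tested in an ADME assay on PC-3 cells (Homo sapiens) for cytotoxicity, read by sulforhodamine B assay, with a stated time of 48 h, tested at 10 uM (a higher number here means more inhibition at the concentration tested (going by the name of the read-out), a lower number less inhibition), and gives 7.43%, which stands as the lowest of the two numbers so far; its nearest neighbour is compound 2 `COc1nc2ccc(Br)cc2cc1C(c1ccccc1)n1cc(-c2ccc(OC(F)(F)F)cc2)nn1`, which in this assay gives 21.6%. Within the data shown here, the only measured step, a number 14.2 percentage points higher from compound 1 to compound 2 (beyond the scatter), exchanges one substituent on the pendant aromatic ring for another and lies beyond the scatter, though it remains modest in size.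

Compound 3 `COc1nc2ccc(Br)cc2cc1C(c1ccccc1)n1cc(CO)nn1` is not yet measured. Its change from compound 1 is hydroxymethyl in place of 4-bromophenyl on an aromatic carbon. The measured step bears on it only loosely: there the 4-bromophenyl ring was kept and only its bromo exchanged, whereas here the whole 4-bromophenyl leaves and a hydroxymethyl enters in its place. Among the measured compounds shown here, no measured pair shows what removing that ring does, so the expectation rests on the two low values of compound 1 and compound 2 alone and carries a wide range. The expected step is a number 2.6 percentage points higher from compound 1 to compound 3 (within the scatter), meaning no change beyond the scatter. Compound 3 is therefore estimated at 10%, within a range from -5% to 30%.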

Compound 3, a percentage reported as inhibition, at one concentration (the size of the read-out at that concentration, not a potency): 4.65%
Estimate against measurement, compound 3: 5.4 percentage points above, within the range that was stated.
By their numbers in this assay, from the lowest: compounds 3 and 1 (each within the scatter of the next); then compound 2.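

Within the data shown here, with hydroxymethyl in place of 4-bromophenyl on this aromatic carbon, the result is a number 2.8 percentage points lower from compound 1 to compound 3 (within the scatter) in this assay, so for the first time the group at this position itself is exchanged rather than a substituent on its pendant ring, and for this pair the exchange gives no difference beyond the scatter. The same exchange made from the trifluoromethoxy-bearing ring gives a number 17 percentage points lower from compound 2 to compound 3 (beyond the scatter), so an aromatic ring at this place does not by itself set compound 1 apart from compound 3, and among these three compounds only the 4-(trifluoromethoxy)phenyl group separates from hydroxymethyl, by a modest step. No measurement at hand gives a reason for either step.

The compounds shown leave open whether a non-aromatic group other than hydroxymethyl behaves the same way at this carbon, for example an aminomethyl group, a carboxylic acid or a longer chain ending in a hydroxyl. They also leave open whether the trifluoromethoxy substituent is needed for the step seen with compound 2, which a pendant phenyl ring carrying a methoxy or a nitrile would begin to test.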